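A few compounds are considered here, and "the series" means these few. Any claim that something is new, unique, unknown or untested is made for them only; others in the source may bear on it.

In a functional assay on HeLa cells (Homo sapiens) for inhibition, read by MTT assay, with a stated time of 48 h (on this read-out lower numbers stand for stronger inhibition and higher numbers for weaker inhibition), compound 1 `COc1ccc2c(=O)c(/C=C/C(=O)Nc3cccc(C)c3)coc2c1` gives > 100000 nM, which is a limit of the assay. Within the data shown here, compound 2 `COc1ccc2c(=O)c(/C=C/C(=O)Nc3ccccc3Cl)coc2c1` gives 22400 nM, the only actual number so far. Among the measured compounds shown here, the single measured step is an at least 4.4-fold lower number from compound 1 to compound 2 (0.64 log units; beyond the scatter). Compound 3 `COc1cccc(NC(=O)/C=C/c2coc3cc(OC)ccc3c2=O)c1` differs from compound 2 by 3-methoxyphenyl in place of 2-chlorophenyl on an amide-type nitrogen, with 3-methoxyphenyl in place of 2-chlorophenyl on an amide-type nitrogen. The entering group resembles the 3-methylphenyl of compound 1 at > 100000 nM more than the leaving one, so a modest rise is expected. The expected change is a 2.2-fold higher number from compound 2 to compound 3 (0.35 log units; beyond the scatter). The estimated value for compound 3 is 50000 nM, within a range of 18000 nM to 100000 nM.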

Compound 3, half-maximal inhibitory concentration: 19200 nM
Compound 3: middle estimate off by 2.6-fold (0.42 log units), on the high side; low and high end bracket the measured number.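

In this assay, the 2-chlorophenyl and 3-methoxyphenyl groups on the amide-type nitrogen are not told apart, with a 1.2-fold lower number from compound 2 to compound 3 (0.07 log units; within the scatter). Exchanging only the methyl on the aromatic carbon for methoxy gives an at least 5.2-fold lower number from compound 1 to compound 3 (0.71 log units; beyond the scatter), so a measurable number does not depend on chlorine. Compound 1 stands at a limit of the assay, not at a number: the limit of > 100000 nM in this assay, at which 1 of the 3 values shown sits.

As far as these compounds go, what remains open is whether an amine or a carboxylic acid on this phenyl ring would shift the number beyond the scatter.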